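A few compounds are considered here, and "the series" means these few. Any claim that something is new, unique, unknown or untested is made for them only; others in the source may bear on it.

Measured compounds:
- compound 1, `Cc1ccc([C@@]2(CO)NC[C@H](O)[C@H]2O)cc1` — 17000 nM
- compound 2, `Cc1ccc([C@]2(CO)NC[C@@H](O)[C@@H]2O)cc1` — 43000 nM
- compound 3, `OC[C@@]1(c2ccc(F)cc2)NC[C@@H](O)[C@@H]1O` — 12000 nM

In an assay on isolated protein for inhibition of lysosomal alpha-glucosidase (Rattus norvegicus), read by colorimetric assay (a higher number here means a weaker inhibitor, a lower number a stronger inhibitor), compound 1 gives 17000 nM, the second highest of the three numbers; its nearest neighbour is compound 3, with a gap that lies within the scatter, while compound 2 sits furthest away. The mirror image, compound 2, shows a 2.5-fold higher number from compound 1 to compound 2 (0.40 log units; beyond the scatter) — a difference that rests on the fact that compounds 1 and 2 differ only in the configuration as drawn alone. From compound 2 to compound 3, fluoro in place of methyl on the aromatic carbon brings a 3.6-fold lower number from compound 2 to compound 3 (0.55 log units; beyond the scatter).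

Compound 4, `OC[C@]1(c2ccccc2)NC[C@H](O)[C@H]1O`, is the next point. It differs from compound 1 by hydrogen in place of methyl on an aromatic carbon. For the measured compounds named here, no measured step removes the methyl outright, but the step from compound 2 to compound 3 is the one that bears on it, since it also alters the group on that aromatic carbon and gave a modest lowering. A change of comparable or smaller size, toward a lower number or none beyond the scatter, is therefore what is expected in this assay for compound 4. Compound 4 is estimated at 10000 nM, with a range from 4000 nM to 25000 nM. That estimate means a 1.7-fold lower number from compound 1 to compound 4 (0.23 log units; within the scatter).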

Compound 4, half-maximal inhibitory concentration: 190 nM
For compound 4 the middle estimate is 53-fold (1.72 log units) above the measured one; the whole stated range lies above it.
By their numbers in this assay, from the lowest: compound 4; then compounds 3 and 1 (each within the scatter of the next); then compound 2.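

Taking off the one methyl on the aromatic carbon para to a group of 9 heavy atoms, with hydrogen in its place, gives an 89-fold lower number from compound 1 to compound 4 (1.95 log units; beyond the scatter) in this assay, a large step for the loss of a single carbon. The earlier change at this same carbon, a 3.6-fold lower number from compound 2 to compound 3 (0.55 log units; beyond the scatter), was only modest and swapped one substituent for another in the configuration of compound 2, so it gave no sign that this position could matter so much; the new step shows that, in the configuration of compound 1, the unsubstituted aromatic ring stands far apart from its methyl analogue, and compound 4 has the lowest number of the four. Nothing given here accounts for the size of this step.

The compounds shown leave open whether any group at this carbon in the configuration of compound 4 would raise the number as methyl does, or whether that holds for methyl alone, as a fluoro, a chloro, a methoxy or an amine there could tell. They also leave open how the mirror image of compound 4 compares, and so whether the effect of hydrogen in place of methyl depends on configuration.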